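Swapping naphthyl for fluoroindolyl on a tetrahydropyridine core

A few compounds are considered here, and "the series" means these few. Any claim that something is new, unique, unknown or untested is made for them only; others in the source may bear on it.

Measured so far:
compound 1, `NC(=O)c1ccc2c(c1)CCOC2CCN1CC=C(c2cccc3ccccc23)CC1` — 5.4 nM
compound 2, `C[C@H]1CC(c2c[nH]c3cc(F)ccc23)CCN1CCC1OCCc2cc(C(N)=O)ccc21` — 28 nM

In an assay on cells for binding affinity to 5-hydroxytryptamine receptor 1D (Homo sapiens), read by radioligand binding (on this read-out higher numbers stand for weaker inhibition and lower numbers for stronger inhibition), compound 1 gives 5.4 nM, the lowest of the two numbers in hand. Compound 2 differs from compound 1 in several places at once; in this assay compound 2 gives 28 nM, and the gap between the two lies beyond the usual scatter, but since the compounds differ in more than one place nothing can be pinned on a single change.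

Compound 3, `NC(=O)c1ccc2c(c1)CCOC2CCN1CC=C(c2c[nH]c3ccc(F)cc23)CC1`, is the untested member of the set. It keeps the shared core of compound 1 and carries 5-fluoro-1H-indol-3-yl in place of naphthalen-1-yl on a double-bonded ring carbon, the new group sitting three ring bonds from the ring nitrogen. Among the compounds with values here, no single-change step is known here, so the expected direction rests on the two numbers alone. Compound 3 is expected to give 12 nM in this assay, within a range of 3.5 nM to 40 nM, which amounts to an estimated step of a 2.2-fold higher number from compound 1 to compound 3 (0.35 log units; beyond the scatter) at or just beyond the scatter toward a weaker number.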

Compound 3, inhibition constant: 130 nM
Compound 3: the middle estimate sits 11-fold (1.03 log units) below what was measured; measured number outside the range, above it.
By their numbers in this assay, from the lowest: compound 1; then compound 2; then compound 3.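

In this assay, within the data shown here, the replacement of naphthalen-1-yl by 5-fluoro-1H-indol-3-yl on a double-bonded ring carbon gives a 24-fold higher number from compound 1 to compound 3 (1.38 log units; beyond the scatter), the first change in the set that can be read on its own, and a large one. It shows that this position, three ring bonds from the ring nitrogen, clearly distinguishes between these two groups, even though they have the same count of heavy atoms. Nothing measured here bears on why the step is so large.

Which part of the change carries the step remains open: the fluorine, the indole ring with its hydrogen-bond donor, or both. The compounds shown cannot separate these, and an unsubstituted 1H-indol-3-yl or a 5-fluoronaphthalen-1-yl at the same place would help to do so.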